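The source may report more compounds than this note shows. Statements on the series, on what has been measured and on what is new or still open speak of the compounds shown alone.

Of the compounds shown here, two carry numbers so far. In a functional assay on SF-295 cells (Homo sapiens) for cytotoxicity, read by sulforhodamine B assay, with a stated time of 48 h (a lower number here means a stronger inhibitor of growth, a higher number a weaker inhibitor of growth), compound 1 `ClCc1ccc(Cn2cnc3nc(Cl)nc(Cl)c32)cc1` gives 3310 nM, the lowest of the two values; the nearest is compound 2 `ClCc1ccc(Cn2cnc3c(Cl)nc(Cl)nc32)cc1`, which in this assay gives 19500 nM, a gap beyond the scatter. Compound 3 `ClCc1ccc(Cn2cnc3ncnc(Cl)c32)cc1` is not yet measured. It differs from compound 1 by hydrogen in place of chloro on an aromatic carbon. Among the compounds with values here, no measured pair shows this step, so the direction is open; a modest loss in this assay is expected, and the step from compound 1 to compound 3 is estimated at a 2.1-fold higher number from compound 1 to compound 3 (0.33 log units; beyond the scatter). Compound 3 is therefore expected at 7000 nM, within 2500 nM to 20000 nM.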

Compound 3, concentration for total growth inhibition: 5010 nM
The estimate for compound 3 lay 1.4-fold (0.15 log units) above the measured number, and the stated range covers the measured number.
By their numbers in this assay, from the lowest: compounds 1 and 3 (each within the scatter of the next); then compound 2.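

In this assay, hydrogen in place of chloro on an aromatic carbon between two ring nitrogen atoms gives a 1.5-fold higher number from compound 1 to compound 3 (0.18 log units; within the scatter), so the growth inhibition seen with compound 1 does not depend on this chloro group. Within the data shown here, this is the first reading of any single change, and it applies to this position only. No measurement available here offers an explanation for this result.

Still open, on these data alone, is whether an amine or a methoxy group at this carbon would shift the number. As far as these compounds go, the effect of replacing the remaining chloro group of compound 3, or its chloromethyl group, is also open.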